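The compounds below may be only part of what the source reports. "The series", "measured", "known", "first", "only" and "open" are said of these compounds alone.

Measured in a functional assay on A549 cells (Homo sapiens) for cytotoxicity, read by MTT assay, with a stated time of 72 h (on this read-out higher numbers stand for weaker inhibition and lower numbers for stronger inhibition), so far:
- compound 1 `CNC(=O)c1cc(Oc2ccc(C(=O)/C=C/c3ccccc3)cc2)ccn1` gives 5040 nM here
- compound 2 `CNC(=O)c1cc(Oc2ccc(C(=O)/C=C/c3ccc(F)cc3)cc2)ccn1` gives 18600 nM here
- compound 3 `CNC(=O)c1cc(Oc2ccc(C(=O)/C=C/c3ccc(Cl)cc3Cl)cc2)ccn1` gives 9460 nM here

Compound 3 lies within the scatter of both other compounds, through a 1.9-fold higher number from compound 1 to compound 3 (0.27 log units; within the scatter) and a 2.0-fold lower number from compound 2 to compound 3 (0.29 log units; within the scatter) as its two steps. Compound 4 `CNC(=O)c1cc(Oc2ccc(C(=O)/C=C/c3cccc(Cl)c3Cl)cc2)ccn1` has 2,3-dichlorophenyl in place of 2,4-dichlorophenyl on a double-bonded chain carbon bound to a double-bonded chain carbon. For the measured compounds named here, those two steps are the closest precedents, though no measured pair shows this exact exchange. Going by the values given here, the only step beyond the scatter, a 3.7-fold higher number from compound 1 to compound 2 (0.57 log units; beyond the scatter), is modest and concerns fluoro in place of hydrogen. No step beyond the scatter is therefore expected in this assay, and no direction is favoured. The estimated step is a 1.1-fold lower number from compound 3 to compound 4 (0.02 log units; within the scatter) on present data. For compound 4 the expected value is 9000 nM, with an estimated range from 4000 nM to 20000 nM in this read-out.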

Compound 4, half-maximal inhibitory concentration: > 50000 nM
Compound 4 was reported as a limit (the forecaster's own chance of this, stated with the estimate: 5%); at least 5.5-fold (0.74 log units) between middle value and limit.
By their numbers in this assay, from the lowest: compounds 1, 3 and 2 (each within the scatter of the next, the first and the last beyond it). At a limit, above all of these: compound 4.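

Compound 4 is reported only as a limit in this assay: the limit of > 50000 nM in this assay, at which 1 of the 4 values shown sits.

The two dichlorophenyl groups hold the same atoms joined differently, yet the exchange gives an at least 5.2-fold higher number from compound 3 to compound 4 (0.72 log units; beyond the scatter), so on this double-bonded chain carbon the chlorine arrangement alone can shift the read-out beyond the scatter. The other steps to this limit, an at least 2.6-fold higher number from compound 2 to compound 4 (0.42 log units; beyond the scatter) and an at least 9.9-fold higher number from compound 1 to compound 4 (0.99 log units; beyond the scatter), also lie beyond the scatter and share its direction.

Going by these compounds, the actual value of compound 4 remains unknown. Also open, on these data alone, is how an amine or a carboxylic acid on this ring would read out here.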